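The compounds below may be only part of what the source reports. "The series", "measured", "known", "first", "only" and "open" are said of these compounds alone.

Working notes on the series in a functional assay on WHCO1 cells (Homo sapiens) for antiproliferative activity, read by MTT assay, with a stated time of 48 h; a higher number here means a weaker inhibitor, a lower number a stronger inhibitor. Compound 1 `CCC[S+]([O-])C/C=C\SSC` gives 26000 nM, compound 2 `CCCSS/C=C\C[S+]([O-])CCC` gives 18000 nM and compound 3 `C=CCSS/C=C\C[S+]([O-])CCC` gives 23000 nM. Compound 2 therefore stands level with the other two, and no ranking can be read from these numbers.

The next compound is compound 4 `CCCSS/C=C/C[S+]([O-])CCC`, which is compared with compound 2: the two compounds have the same atoms and bonds; at least one stereo element is drawn with a configuration in one of them and without one in the other: 1 of 2 stereo elements differ; a double bond is drawn Z in compound 2 and E in compound 4. Put simply, a double bond is drawn Z in compound 2 and E in compound 4.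

Among the compounds with values here, no measured step tests this change directly, since all three measured compounds carry the Z double bond. The available steps concern only the group on a saturated chain carbon bound to a sulfur: a 1.4-fold lower number from compound 1 to compound 2 (0.16 log units; within the scatter), a 1.1-fold lower number from compound 1 to compound 3 (0.05 log units; within the scatter) and a 1.3-fold higher number from compound 2 to compound 3 (0.11 log units; within the scatter). They show that the series has stayed flat so far, but they say nothing firm about the E double bond, so the range has to stay wide.

With no evidence for a shift in either direction, and with compound 2 at 18000 nM as the anchor, no step beyond the scatter is expected in this assay. The estimated step is a 1.1-fold higher number from compound 2 to compound 4 (0.05 log units; within the scatter). For compound 4 the expected value is 20000 nM, with an estimated range from 10000 nM to 38000 nM.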

Compound 4, half-maximal inhibitory concentration: 24000 nM
Beside the measured number, compound 4's estimate is 1.2-fold (0.08 log units) below it; the measured number falls inside the stated range.
By their numbers in this assay, from the lowest: compounds 2, 3, 4 and 1 (each within the scatter of the next).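

In this assay, the switch of the double bond from Z in compound 2 to E in compound 4 gives a 1.3-fold higher number from compound 2 to compound 4 (0.12 log units; within the scatter). Within the data shown here, the earlier compounds all carry the Z double bond and vary only the group on a saturated chain carbon bound to a sulfur, so this pair is the first direct test of the double-bond geometry, and it separates the two compounds by no more than the scatter. The flat picture therefore extends to this change for this one pair, with the reading resting on a single structural fact: the fact that one of compounds 2 and 4 is drawn with a defined configuration and the other without, at the place where they differ.

It remains open whether the E double bond would read the same way alongside the hydrogen of compound 1 or the vinyl of compound 3, as the only E compound shown carries the ethyl of compound 2. Also open, from the compounds shown here alone, is whether an amine, a carboxylic acid or a longer chain in place of ethyl on the saturated chain carbon bound to a sulfur would move the number beyond the scatter in either double-bond geometry.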